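A few compounds are considered here, and "the series" means these few. Any claim that something is new, unique, unknown or untested is made for them only; others in the source may bear on it.

Working notes on the series. Compound 3 `CCCC(=O)N(CCC(=O)c1c(CC)nc(CCC)n1Cc1ccc(-c2ccccc2S(=O)(=O)NC(=O)OCCC(C)C)cc1)c1cccnc1` is the reference for the step below. In an assay on isolated protein for inhibition of Type-2 angiotensin II receptor (Rattus norvegicus) (on this read-out higher numbers stand for weaker inhibition and lower numbers for stronger inhibition), compound 3 gives 1 nM, the highest of the three numbers in hand. The nearest is compound 2 `CCCc1nc(CC)c(C(=O)CCN(C(=O)c2cccnc2)c2cccnc2)n1Cc1ccc(-c2ccccc2S(=O)(=O)NC(=O)OCCC(C)C)cc1F`, which in this assay gives 0.22 nM, and the lowest is compound 1 `CCCC(=O)N(CCC(=O)c1c(CC)nc(CCC)n1Cc1ccc(-c2ccccc2S(=O)(=O)NC(=O)OCCC(C)C)cc1F)c1ccccc1`, which in this assay gives 0.15 nM; both gaps to compound 3 are beyond the scatter. Going by the values given here, compound 2 and compound 1 differ from compound 3 in more than one place, so no single step among the measured compounds can be read off.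

Compound 4 `CCCc1nc(CC)c(C(=O)CCN(C(=O)c2cccnc2)c2cccnc2)n1Cc1ccc(-c2ccccc2S(=O)(=O)NC(=O)OCCC(C)C)cc1` has not been measured in this assay. It differs from compound 3 by pyridin-3-yl in place of propyl on a carbonyl carbon. Among the compounds with values here, the only guide is that compound 2, which also carries the pyridin-3-yl on the carbonyl, gives 0.22 nM, a lower number than compound 3. From compound 3 to compound 4 the step is expected to be a 1.4-fold lower number from compound 3 to compound 4 (0.15 log units; within the scatter), at most a modest move toward a lower number and possibly none beyond the scatter. Compound 4 is therefore estimated at 0.7 nM, with a range of 0.25 nM to 2.5 nM.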

Compound 4, half-maximal inhibitory concentration: 1 nM
For compound 4 the middle estimate is 1.4-fold (0.15 log units) below the measured one, within the range that was stated.
By their numbers in this assay, from the lowest: compounds 1 and 2 (each within the scatter of the next); then compounds 3 and 4 (each within the scatter of the next).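

In this assay, pyridin-3-yl in place of propyl on the carbonyl carbon whose other neighbour is the amide-type nitrogen gives no change at the digits printed from compound 3 to compound 4 (within the scatter), so this position shows no move beyond the scatter for this exchange in the pair. Hydrogen in place of fluoro on an aromatic carbon gives a 4.5-fold higher number from compound 2 to compound 4 (0.66 log units; beyond the scatter), the first single-place reading for the fluoro group and the only one of the two steps beyond the scatter. Nothing in hand accounts for either step. As far as these compounds go, whether the fluoro step keeps its size with propyl rather than pyridin-3-yl on the carbonyl carbon remains open. Also open, from the compounds shown here alone, is how a longer chain, an amine or a carboxylic acid at that carbonyl carbon would read in this assay, and whether chloro would match fluoro on the aromatic carbon.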